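This account rests on a few compounds, and the source may have more. Where it says the series, first, only, none or still open, it means among the compounds named here.

Compound 1 `C=C[C@@](C)(/C=C/c1ccc(Nc2ccc(OC)cc2)cc1)CCC=C(C)C` stands in a functional assay on HepG2 cells (Homo sapiens) for cytotoxicity, with a stated time of 72 h (a higher number here means that more compound is needed for the effect, a lower number that less compound is needed), only at a limit of the assay: in this assay compound 1 gives > 52000 nM. Compound 2 `C=C[C@@](C)(/C=C/c1ccc(Nc2ccc(OC)c(OC)c2)cc1)CCC=C(C)C` likewise gives only a limit, > 52000 nM. The step that the two limits leave unreadable from compound 1 to compound 2 therefore cannot be read, since (the limit of > 52000 nM in this assay, at which 2 of the 2 values shown sit). Within the data shown here, the change to compound 3 `C=C[C@@](C)(/C=C/c1ccc(-c2ccc(Cl)cc2)cc1)CCC=C(C)C` is 4-chlorophenyl in place of (4-methoxyphenyl)amino on an aromatic carbon, and no measured step bears on it. With both shown values sitting at the limit, compound 3 is expected to give a value near that limit as well, an expected step that the limit leaves unreadable from compound 1 to compound 3; the estimate for compound 3 is 60000 nM, ranging from 15000 nM to 250000 nM.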

Compound 3, half-maximal effective concentration: > 52000 nM
Compound 3 ended at the assay's limit; the forecaster's own chance of this, stated with the estimate: 70%; the middle value lies beyond the limit too.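

No new step can be read between compound 1 and compound 3, since each gives only a limit: the limit of > 52000 nM in this assay, at which 3 of the 3 values shown sit. The compounds shown leave open which change to the shared core, if any, would give a measurable value in this assay.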